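The compounds below may be only part of what the source reports. "The series", "measured", "known", "first", "only" and "open" are said of these compounds alone.

Measured compounds:
Compound 1 `C/C(=N\Nc1ccccc1)c1c(O)c2ccccc2oc1=O`: 27000 nM
Compound 2 `C/C(=N\Cc1cccnc1)c1c(O)c2ccccc2oc1=O`: 17000 nM
Compound 3 `C/C(=N\Cc1ccccn1)c1c(O)c2ccccc2oc1=O`: 22000 nM

In an assay on isolated protein for inhibition of myosin-2 (Bos taurus), read by spectrophotometry, with a stated time of 24 min (on this read-out higher numbers stand for weaker inhibition and lower numbers for stronger inhibition), compound 3 stands second highest of the three numbers; its nearest neighbour is compound 1, with a 1.2-fold lower number from compound 1 to compound 3 (0.09 log units; within the scatter) separating the two, and its furthest is compound 2, with a 1.3-fold higher number from compound 2 to compound 3 (0.11 log units; within the scatter) between them. The step of a 1.6-fold lower number from compound 1 to compound 2 (0.20 log units; within the scatter) likewise stays within the scatter, so none of the three changes on the double-bonded nitrogen moved this assay by more than repeated measurement would.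

Compound 4 `CCC(C)/N=C(\C)c1c(O)c2ccccc2oc1=O` differs from compound 3 by sec-butyl in place of (pyridin-2-yl)methyl on a double-bonded nitrogen. Among the measured compounds shown here, no measured step exchanges a ring-bearing group for a chain at this position, so the bearing of the earlier steps is indirect: they show only that the group on the double-bonded nitrogen, whether anilino, (pyridin-3-yl)methyl or (pyridin-2-yl)methyl, left this assay unchanged beyond the scatter. On that basis no step beyond the scatter is expected. The expected step is a 1.1-fold higher number from compound 3 to compound 4 (0.06 log units; within the scatter). Compound 4 is therefore estimated at 25000 nM, with a range from 8000 nM to 80000 nM.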

Compound 4, half-maximal inhibitory concentration: >= 100000 nM
Compound 4: only a limit was reported (the forecaster's own chance of this, stated with the estimate: 15%); at least 4.0-fold (0.60 log units) between middle value and limit.
By their numbers in this assay, from the lowest: compounds 2, 3 and 1 (each within the scatter of the next). At a limit, above all of these: compound 4.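

In this assay compound 4 gives >= 100000 nM, which is a limit of the assay and not a number. Where the earlier changes on the double-bonded nitrogen all stayed within the scatter, this one goes beyond it in every comparison: an at least 4.5-fold higher number from compound 3 to compound 4 (0.65 log units; beyond the scatter), an at least 5.8-fold higher number from compound 2 to compound 4 (0.76 log units; beyond the scatter) and an at least 3.7-fold higher number from compound 1 to compound 4 (0.56 log units; beyond the scatter). The position is therefore not indifferent to its group, since sec-butyl, the only group shown without a ring, separates from anilino, (pyridin-3-yl)methyl and (pyridin-2-yl)methyl.

With a single ringless group, the compounds shown cannot tell whether the missing ring or the sec-butyl chain itself accounts for this step. As far as these compounds go, whether a straight butyl chain or a cyclohexylmethyl group at this place would fall with compound 4 or with the other three remains open.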